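Removing the Nitro Group from the Weakest Compound

A few compounds are considered here, and "the series" means these few. Any claim that something is new, unique, unknown or untested is made for them only; others in the source may bear on it.

Measured in a functional assay on DU-145 cells (Homo sapiens) for antiproliferative activity, read by MTT assay, with a stated time of 72 h; on this read-out lower numbers stand for stronger inhibition and higher numbers for weaker inhibition:
- compound 1 `O=C(COc1ccc(C(=O)/C=C/c2ccc(Cl)cc2Cl)cc1)N[C@H]1CCOC1=O` gives 8610 nM
- compound 2 `O=C(COc1ccc(C(=O)/C=C/c2ccccc2Cl)cc1)N[C@H]1CCOC1=O` gives 3240 nM
- compound 3 `O=C1OCC[C@@H]1NC(=S)SCCOc1ccc([N+](=O)[O-])cc1` gives 31000 nM

Compound 3 stands highest of the three numbers, which on this read-out means the weakest inhibition of cell growth. Compound 1 is its nearest neighbour, and compound 2 lies furthest from it.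

Compound 4 `O=C1OCC[C@@H]1NC(=S)SCCOc1ccccc1` differs from compound 3 in one place: hydrogen in place of nitro on an aromatic carbon. The group that leaves sits para to a large group on the six-membered aromatic ring of carbon only.

Among the compounds with values here, only one measured step removes a single substituent from an aromatic ring: a 2.7-fold lower number from compound 1 to compound 2 (0.42 log units; beyond the scatter). That step takes away a chloro on a different core, so it bears only loosely on the removal of a nitro here. It does show that losing one ring substituent can move this assay by a modest amount, and in the direction of a lower number. With so thin a basis, the expected step is small, most likely within the scatter, with a slight lean towards a lower number.

Compound 4 is therefore estimated at 20000 nM, with a range from 7000 nM to 60000 nM. This estimate corresponds to a 1.6-fold lower number from compound 3 to compound 4 (0.19 log units; within the scatter).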

Compound 4, half-maximal inhibitory concentration: 63800 nM
Beside the measured number, compound 4's estimate is 3.2-fold (0.50 log units) below it, outside the stated range (above it).
By their numbers in this assay, from the lowest: compound 2; then compound 1; then compound 3; then compound 4.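

In this assay, taking the nitro group away from the place para to a large group gives a 2.1-fold higher number from compound 3 to compound 4 (0.31 log units; beyond the scatter), so on this core a bare aromatic carbon at that place goes with weaker inhibition of cell growth than the nitro-bearing ring does. This runs opposite to the only other single-substituent removal shown, a 2.7-fold lower number from compound 1 to compound 2 (0.42 log units; beyond the scatter), which loses a chloro on a different core, so the loss of a ring substituent has no single direction across these two pairs, and the earlier step could not be carried over to this place. The data shown offer no measurement that accounts for this difference between the two removals.

Going by these compounds, with only nitro and hydrogen compared at this place, it remains open whether the gain belongs to the nitro group itself or whether another substituent, such as a chloro, a methoxy, an amine or a carboxylic acid, would match or exceed it. Also open, on these data alone, is whether a nitro group on another carbon of the same ring would give a similar result.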